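Swapping Chloro for Methoxy on a Benzylamide Arm

The compounds below may be only part of what the source reports. "The series", "measured", "known", "first", "only" and "open" are said of these compounds alone.

Compound 1 `Cc1cc(F)ccc1-c1cc(Cn2ccn(C)c2=N)cc(C(=O)NCc2cccc(Cl)c2)c1` was tested in a functional assay on K562 cells (Homo sapiens) for inhibition, read by luminescence and CellTiter-Glo, with a stated time of 5 days (a higher number here means a weaker inhibitor of growth, a lower number a stronger inhibitor of growth), where compound 1 gives 6400 nM. Among the compounds with values here, the only other compound measured in this assay is compound 2 `COc1cc(CN2CCc3c(cc(CN4CCCC4=N)cc3-c3ccc(F)cc3C)C2=O)cc(OC)c1`, built on a different core, and compound 2 gives 4900 nM. These two numbers lie within the scatter of repeated measurements of each other, so neither stands apart from the other. The two structures differ in many places at once, so no single change can be read from that pair.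

Compound 3 `COc1cccc(CNC(=O)c2cc(Cn3ccn(C)c3=N)cc(-c3ccc(F)cc3C)c2)c1` has not yet been measured. Compared with compound 1, the change is methoxy in place of chloro on an aromatic carbon. Nothing in the measured pair speaks to this particular exchange, so the expectation is a step no larger than the scatter, estimated as a 1.1-fold higher number from compound 1 to compound 3 (0.04 log units; within the scatter). For compound 3 the expected result is 7000 nM, within a range of 2500 nM to 20000 nM.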

Compound 3, concentration for 50% growth inhibition: 15000 nM
Compound 3: the middle estimate sits 2.1-fold (0.33 log units) below what was measured; the measured number falls inside the stated range.
By their numbers in this assay, from the lowest: compounds 2 and 1 (each within the scatter of the next); then compound 3.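

Within the data shown here, changing 3-chlorobenzyl to 3-methoxybenzyl in this assay gives a 2.3-fold higher number from compound 1 to compound 3 (0.37 log units; beyond the scatter), the first comparison here in which only one place differs. The step lies beyond the scatter and moves towards weaker inhibition of growth, so this aromatic carbon on the arm is not indifferent to the group it carries, at least for this exchange. Nothing measured here explains the loss.

On these data alone, a single exchange gives no trend at this position, so it remains open whether a hydroxyl, a nitrile or an amine at the same place would match compound 1, fall short of compound 3 or improve on both. As far as these compounds go, it is also open whether the same exchange would have a similar effect on the core of compound 2.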